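The source may report more compounds than this note shows. Statements on the series, on what has been measured and on what is new or still open speak of the compounds shown alone.

Three compounds built on one shared core were tested in a functional assay on Huh-7 cells (Homo sapiens) for cytotoxicity, read by CCK-8 assay, with a stated time of 72 h; on this read-out lower numbers stand for stronger inhibition and higher numbers for weaker inhibition. Compound 1 `C=CCn1c(=O)/c(=C\c2ccc(Cl)c(Cl)c2)[nH]c(=O)/c1=C\c1ccccc1` gives "not active" (no number reported) in this assay. Compound 3 `C=CCn1c(=O)/c(=C\c2cccc(Br)c2)[nH]c(=O)/c1=C\c1cccc(Br)c1` likewise gives "not active" (no number reported). Compound 2 `C=CCn1c(=O)/c(=C\c2cccc(Br)c2)[nH]c(=O)/c1=C\c1ccccc1OC` gives 2300 nM in this assay, and it is the only one of the three with a number attached; the other two entries carry no number at all, so compound 2 stands alone as the single measured point of the set.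

Compound 4 `C=CCn1c(=O)/c(=C\c2cccc(Cl)c2Cl)[nH]c(=O)/c1=C\c1ccccc1OC` has not yet been measured in this assay. It differs from compound 2 in one place: 2,3-dichlorophenyl in place of 3-bromophenyl on a double-bonded chain carbon bound to an aromatic carbon. Among the compounds with values here, no step between two measured compounds is available here, so there is nothing in the set against which this change can be compared, and the two compounds without a number offer no guide to its direction. The step is expected to be small, falling within the scatter or showing a mild weakening: from compound 2 to compound 4 the expected change is a 1.5-fold higher number from compound 2 to compound 4 (0.18 log units; within the scatter). Compound 4 is therefore estimated at 3500 nM in this assay, with a range from 900 nM to 15000 nM.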

Compound 4, half-maximal inhibitory concentration: 1200 nM
Compound 4: the middle estimate sits 2.9-fold (0.46 log units) above what was measured, within the range that was stated.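

In this assay, within the data shown here, the exchange gives the first direct comparison in the set: a 1.9-fold lower number from compound 2 to compound 4 (0.28 log units; within the scatter) and so compound 2 and compound 4 cannot be told apart. On a double-bonded chain carbon bound to an aromatic carbon, 2,3-dichlorophenyl and 3-bromophenyl therefore read alike within the usual scatter, and a measurable number remains when one bromine gives way to two chlorines. No measurement at hand explains this outcome.

These two compounds carry only halogens on this aromatic ring, so they say nothing about how a ring bearing an amine or a carboxylic acid would read at the same place. Going by these compounds, whether a longer chain on that carbon would keep a measurable number also remains open.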